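The source may hold more compounds than are shown below. What is called first, only, known or untested is meant among the compounds shown, and "the series" means these compounds.

Three compounds that share one core have been examined in a toxicity assay on HepG2 cells (Homo sapiens) for inhibition, read by CellTiter-Glo, with a stated time of 48 h; a higher number here means a weaker inhibitor, a lower number a stronger inhibitor. Compound 1 `COc1cccc(NC(=O)COc2cc(C)nc3ccc(OC)cc23)c1` gives in this assay > 100000 nM, which is a limit of the assay rather than a number. Compound 2 `COc1ccc2nc(C)cc(OCC(=O)Nc3ccc(Cl)cc3)c2c1` likewise returns in this assay > 100000 nM, again a limit. Compound 3 `COc1ccc2nc(C)cc(OCC(=O)Nc3cccnc3)c2c1` stands in this assay at > 100000 nM, also a limit and not a number. The steps among these three, a step that the two limits leave unreadable from compound 1 to compound 2, a step that the two limits leave unreadable from compound 1 to compound 3 and a step that the two limits leave unreadable from compound 2 to compound 3, cannot be sized, since every one of the three measurements rests at the limit of > 100000 nM in this assay, at which 3 of the 3 values shown sit. Compound 4 `COc1ccc2nc(C)cc(OCC(=O)Nc3nc(C)c(C)s3)c2c1` has not yet been measured in this assay. Its change from compound 3 is 4,5-dimethyl-1,3-thiazol-2-yl in place of pyridin-3-yl on an amide-type nitrogen. For the measured compounds named here, the three unreadable steps are the only evidence that bears on this change, and what they show is that exchanging the group on the amide-type nitrogen among three different groups left each value at the limit. For compound 4 the expected step is accordingly a step that the limit leaves unreadable from compound 3 to compound 4, that is, no readable movement, with the value most likely reported once more only as a limit. Compound 4 is therefore estimated in this assay at 150000 nM, with a range from 50000 nM to 500000 nM.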

Compound 4, half-maximal inhibitory concentration: > 100000 nM
Compound 4 ended at the assay's limit; the forecaster's own chance of this, stated with the estimate: 85%; the middle value lies beyond the limit too.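

In this assay compound 4 gives > 100000 nM, which is a limit and not a number. For the compounds shown here, no step from compound 1, compound 2 or compound 3 to compound 4 can be read, as all four compounds rest at the same limit: the limit of > 100000 nM in this assay, at which 4 of the 4 values shown sit. The compounds shown leave open whether any change to the shared core would yield a readable value in this assay.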